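Removing a Methyl Group: Effect on Measured Solubility

The source may hold more compounds than are shown below. What is called first, only, known or untested is meant among the compounds shown, and "the series" means these compounds.

Compound 1 `Cc1nc(N)nc2c1c(-c1ccc3oc(N)nc3c1)nn2C(C)C` and compound 2 `CC(C)n1nc(-c2ccc3oc(N)nc3c2)c2cnc(N)nc21` share one core and differ by hydrogen in place of methyl on an aromatic carbon. In a physicochemical assay for solubility, read by HPLC, in phosphate buffer, measured as kinetic solubility, with a stated time of 24 h, at 20 degrees C, at pH 7.4, tested at 100 uM (on this read-out higher numbers stand for higher solubility and lower numbers for lower solubility), compound 1 gives 74000 nM, while compound 2 gives 1600 nM, so the change made a 46-fold lower number from compound 1 to compound 2 (1.67 log units; beyond the scatter). Compound 3 `Cc1nc2c(c(-c3ccc4oc(N)nc4c3)nn2C(C)C)c(=O)[nH]1` has another core; the difference between the two cores is not broken down here. In this assay compound 3 gives 3000 nM. Compound 4 `CC(C)n1nc(-c2ccc3oc(N)nc3c2)c2c(=O)[nH]cnc21` has not been measured and differs from compound 3 by hydrogen in place of methyl on an aromatic carbon. This is the same kind of change as from compound 1 to compound 2, but the place differs: in compound 3 the carbon is between two ring nitrogen atoms, meta to a fused ring and para to a fused ring, whereas in compound 1 it was next to the ring nitrogen, ortho to a fused ring and opposite the ring nitrogen. Beside the earlier step of a 46-fold lower number from compound 1 to compound 2 (1.67 log units; beyond the scatter), compound 4 is expected to show a 5.0-fold lower number from compound 3 to compound 4 (0.70 log units; beyond the scatter), a smaller step: the core differs and only one precedent exists. The estimate for compound 4 is 600 nM, expected between 150 nM and 3000 nM.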

Compound 4, solubility: 3000 nM
For compound 4 the middle estimate is 5.0-fold (0.70 log units) below the measured one; measured number inside the range.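

In this assay the swap of methyl for hydrogen gives no change at the digits printed from compound 3 to compound 4 (within the scatter) on this core, against a 46-fold lower number from compound 1 to compound 2 (1.67 log units; beyond the scatter) on the core of compound 1. The large step therefore did not carry over from one core to the other, which shows that a single precedent was a poor guide here; it does not show how such a change behaves in general, since these two pairs differ both in core and in the place of the carbon, and the two cannot be separated. No measurement offered here accounts for the gap between the two steps.

The compounds shown leave open how an ethyl group, an amine or a carboxylic acid on this aromatic carbon would compare with methyl and hydrogen. They also leave open what the same swap would do on a third core.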